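The compounds below may be only part of what the source reports. "The series", "measured", "known", "first", "only" and "open" are said of these compounds alone.

Measured compounds in a functional assay on MCF7 cells (Homo sapiens) for antiproliferative activity, read by CCK-8 assay, with a stated time of 72 h; a lower number here means a stronger inhibitor, a higher number a weaker inhibitor:
compound 1, `COc1cccc(C(=O)Nc2cccc(-c3oc4cc(-c5ccc(F)cc5)ccc4c(=O)c3O)c2)c1`, 15300 nM
compound 2, `Cc1cccc(C(=O)Nc2cccc(-c3oc4cc(-c5ccc(F)cc5)ccc4c(=O)c3O)c2)c1`, 7850 nM
compound 3, `Cc1cc(C(=O)Nc2cccc(-c3oc4cc(-c5ccc(F)cc5)ccc4c(=O)c3O)c2)ccc1F`, 7710 nM

Compound 2 holds the second highest of the three numbers; its nearest neighbour is compound 3, with a 1.0-fold lower number from compound 2 to compound 3 (0.01 log units; within the scatter), and its furthest is compound 1, seen in a 1.9-fold lower number from compound 1 to compound 2 (0.29 log units; within the scatter). Compound 4, `N#Cc1ccc(C(=O)Nc2cccc(-c3oc4cc(-c5ccc(F)cc5)ccc4c(=O)c3O)c2)cc1`, is not yet measured. The change from compound 2 is 4-cyanophenyl in place of 3-methylphenyl on a carbonyl carbon. Among the measured compounds shown here, no measured step involves a cyanophenyl. For the measured compounds named here, the steps that bear on the amide aryl are a 1.9-fold lower number from compound 1 to compound 2 (0.29 log units; within the scatter) and a 2.0-fold lower number from compound 1 to compound 3 (0.30 log units; within the scatter), and both fall within the scatter, as does a 1.0-fold lower number from compound 2 to compound 3 (0.01 log units; within the scatter). The three measured numbers thus sit close together whatever the aryl carries, so the expected step of a 1.0-fold higher number from compound 2 to compound 4 (0.01 log units; within the scatter) is none beyond the scatter. Compound 4 is estimated at 8000 nM, with a range from 3000 nM to 22000 nM.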

Compound 4, half-maximal inhibitory concentration: 2660 nM
Compound 4: the middle estimate sits 3.0-fold (0.48 log units) above what was measured; measured number below the stated range.
By their numbers in this assay, from the lowest: compound 4; then compounds 3, 2 and 1 (each within the scatter of the next).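

In this assay the aryl on the carbonyl carbon proves able to shift the number: 4-cyanophenyl gives a 3.0-fold lower number from compound 2 to compound 4 (0.47 log units; beyond the scatter) and a 2.9-fold lower number from compound 3 to compound 4 (0.46 log units; beyond the scatter) and a 5.8-fold lower number from compound 1 to compound 4 (0.76 log units; beyond the scatter) while the earlier changes among the aryl groups all stayed within the scatter. Among the compounds shown here, these are the first steps at this position beyond the scatter, though each is modest. No measurement shown accounts for them.

Still open, from the compounds shown here alone, is whether the nitrile itself carries the step, and how a carboxylic acid or an amine on the same aryl would read.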